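A few compounds are considered here, and "the series" means these few. Any claim that something is new, unique, unknown or untested is made for them only; others in the source may bear on it.

Measured so far:
compound 1 `C#CCN(c1nc(-c2ccc(C)cc2)no1)C1CCCCC1`: 17.6 ug/mL
compound 2 `C#CCOc1ccc(-c2noc(N(CC#C)C3CCCCC3)n2)cc1`: 101 ug/mL
compound 3 `C#CCN(c1nc(-c2ccc(OC)cc2)no1)C1CCCCC1`: 28 ug/mL

In an ADME assay on RAW264.7 cells (Mus musculus) for cytotoxicity, read by MTT assay, with a stated time of 48 h (on this read-out lower numbers stand for higher toxicity in this test and higher numbers for lower toxicity in this test), compound 3 gives 28 ug/mL, the second highest of the three numbers; it sits near compound 1 (a 1.6-fold higher number from compound 1 to compound 3 (0.20 log units; within the scatter)) and further from compound 2 (a 3.6-fold lower number from compound 2 to compound 3 (0.56 log units; beyond the scatter)). Compound 4 `C#CCN(c1nc(-c2ccc(C#C)cc2)no1)C1CCCCC1` differs from compound 3 by ethynyl in place of methoxy on an aromatic carbon. Within the data shown here, two steps bear on this. The step of a 1.6-fold higher number from compound 1 to compound 3 (0.20 log units; within the scatter) shows that methoxy against methyl on this aromatic carbon changes little. The step of a 3.6-fold lower number from compound 2 to compound 3 (0.56 log units; beyond the scatter) involves the ethynyl, but on a chain carbon bound to the ring oxygen, not directly on the ring, so it is only an indirect guide. Among the measured compounds shown here, no measured step places ethynyl directly on the aromatic carbon. A small step is therefore expected, a 1.1-fold lower number from compound 3 to compound 4 (0.05 log units; within the scatter), possibly within the scatter. Compound 4 is estimated at 25 ug/mL, range 11 ug/mL to 60 ug/mL.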

Compound 4, half-maximal cytotoxic concentration: 13.1 ug/mL
The estimate for compound 4 lay 1.9-fold (0.28 log units) above the measured number; measured number inside the range.
By their numbers in this assay, from the lowest: compounds 4, 1 and 3 (each within the scatter of the next, the first and the last beyond it); then compound 2.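

In this assay ethynyl on this aromatic carbon cannot be told apart from methyl (a 1.3-fold lower number from compound 1 to compound 4 (0.13 log units; within the scatter)) but does separate from methoxy (a 2.1-fold lower number from compound 3 to compound 4 (0.33 log units; beyond the scatter)), although methyl and methoxy lie within the scatter of each other. The step from propargyloxy to ethynyl is the largest at this position (a 7.7-fold lower number from compound 2 to compound 4 (0.89 log units; beyond the scatter)), and among the four groups only propargyloxy stands clear of all the others. Nothing at hand accounts for these differences.

Open, as far as these compounds go, is whether an amine or a carboxylic acid on this aromatic carbon would stay with methyl, methoxy and ethynyl or move towards propargyloxy. Also open, from the compounds shown here alone, is whether a longer chain ending in ethynyl would go further than propargyloxy.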